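This account rests on a few compounds, and the source may have more. Where it says the series, first, only, none or still open, it means among the compounds named here.

Compound 1 `CCCCC(O)Cn1cc(CN(C)CCCc2ccccc2)nn1` stands lowest of the three measured in an assay on nucleic acid for inhibition of Nucleic Acid, read by fluorescence, tested at 100 uM (on this read-out lower numbers stand for less inhibition and higher numbers for more inhibition at the one concentration tested (going by the name of the read-out)), where compound 1 gives 37%. Nearest is compound 2 `CCCCN(CCCC)Cc1cn(CC(O)COC(=O)NCc2ccccc2)nn1`, which in this assay gives 42%, within the scatter; furthest is compound 3 `CCCCC(O)Cn1cc(CN(C)CCC(C)C)nn1`, which in this assay gives 47%, also within the scatter, the step being a number 10 percentage points higher from compound 1 to compound 3 (within the scatter). Compound 4 `CCCCCCCC(=O)OCC(O)Cn1cc(CN(C)CCCc2ccccc2)nn1` differs from compound 1 at another place: (heptylcarbonyl)oxy in place of propyl on a saturated chain carbon, two bonds along the chain from an oxygen on a saturated carbon. Going by the values given here, no measured step touches this place; the only known step, a number 10 percentage points higher from compound 1 to compound 3 (within the scatter), is within the scatter, and compound 2, differing from compound 1 in more than one place, also sits within the scatter. Compound 4 is therefore expected to show no step beyond the scatter, a number 3 percentage points higher from compound 1 to compound 4 (within the scatter). The estimate for compound 4 is 40%, ranging from 25% to 55%.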

Compound 4, a percentage reported as inhibition, at one concentration (the size of the read-out at that concentration, not a potency): 12%
Beside the measured number, compound 4's estimate is 28 percentage points above it, outside the stated range (below it).
By their numbers in this assay, from the lowest: compound 4; then compounds 1, 2 and 3 (each within the scatter of the next).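

In this assay, going by these compounds alone, (heptylcarbonyl)oxy in place of propyl on a saturated chain carbon, two bonds along the chain from an oxygen on a saturated carbon, gives a number 25 percentage points lower from compound 1 to compound 4 (beyond the scatter), the only step here that lies beyond the scatter. This position, which the earlier step did not touch, therefore responds to change, and this change lowers the number. Nothing measured here gives a reason for the drop. The compounds shown leave open whether the ester link or the chain length carries the step; a longer plain alkyl chain or an amide at this place would separate the two.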